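Naphthalen-2-yl Replaces Thiophen-3-yl: Expected Tolerance of Compound 4

This account rests on a few compounds, and the source may have more. Where it says the series, first, only, none or still open, it means among the compounds named here.

Compound 1 `Cc1cc(C#N)cc(C)c1Oc1nc(Nc2ccc(C#N)cc2)ncc1-c1ccco1` gives > 306000 nM in an ADME assay on MT4 cells (Homo sapiens) for cytotoxicity, read by MTT assay, with a stated time of 5 days (a lower number here means that less compound is tolerated, a higher number that more compound is tolerated), a limit of the assay and not a number. Compound 2 `Cc1cc(C#N)cc(C)c1Oc1nc(Nc2ccc(C#N)cc2)ncc1-c1ccc(Cl)cc1` gives 72600 nM in this assay. Compound 3 `Cc1cc(C#N)cc(C)c1Oc1nc(Nc2ccc(C#N)cc2)ncc1-c1ccsc1` gives 3920 nM in this assay.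

Among the two numbers shown, compound 3 has the lowest; its nearest neighbour is compound 2, with a 19-fold lower number from compound 2 to compound 3 (1.27 log units; beyond the scatter). Compound 1 sits at the limit of > 306000 nM in this assay, at which 1 of the 3 values shown sits, so its step to compound 3 is known only as a bound, an at least 78-fold lower number from compound 1 to compound 3 (1.89 log units; beyond the scatter). Both changes at the same position, 4-chlorophenyl in place of furan-2-yl with an at least 4.2-fold lower number from compound 1 to compound 2 (0.62 log units; beyond the scatter) and thiophen-3-yl in place of 4-chlorophenyl, moved the number downward.

Compound 4 `Cc1cc(C#N)cc(C)c1Oc1nc(Nc2ccc(C#N)cc2)ncc1-c1ccc2ccccc2c1` differs from compound 3 in one place: naphthalen-2-yl in place of thiophen-3-yl on an aromatic carbon. Among the measured compounds shown here, no measured pair here exchanges a five-membered ring for two fused six-membered rings of carbon only, so the step from compound 3 to compound 4 has no direct precedent. The measured steps show that swapping the group at this position can shift the number strongly, and all three measured shifts went in the same direction. Compound 4 is therefore expected to remain near compound 3 or somewhat lower, a 1.6-fold lower number from compound 3 to compound 4 (0.20 log units; within the scatter). The estimate for compound 4 is 2500 nM, between 600 nM and 10000 nM.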

Compound 4, half-maximal cytotoxic concentration: 8460 nM
Compound 4: middle estimate off by 3.4-fold (0.53 log units), on the low side, within the range that was stated.
By their numbers in this assay, from the lowest: compound 3; then compound 4; then compound 2. At a limit, above all of these: compound 1.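

Naphthalen-2-yl brings the first measured step at this position that raises the number in this assay, a 2.2-fold higher number from compound 3 to compound 4 (0.33 log units; beyond the scatter), so the three earlier downward steps do not make a one-way trend. Naphthalen-2-yl, with more heavy atoms than thiophen-3-yl, did not lower the number further, and compound 3 remains the lowest of the compounds with a measured number. Two groups built on six-membered aromatic rings of carbon also remain well apart, an 8.6-fold lower number from compound 2 to compound 4 (0.93 log units; beyond the scatter), which shows that such a ring alone does not fix the number here. Compound 1 gives a limit and not a number, so its step, an at least 36-fold lower number from compound 1 to compound 4 (1.55 log units; beyond the scatter), is only a bound: the limit of > 306000 nM in this assay, at which 1 of the 4 values shown sits.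

The compounds shown leave open whether the number at this position follows the size of the group, the hetero atom in the ring, or the substituent on it, and an unsubstituted phenyl or a naphthalen-1-yl would help to separate these. All the groups shown are aromatic rings, so they say nothing about a saturated ring such as cyclohexyl, or about an amine or a carboxylic acid on the ring.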